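A few compounds are considered here, and "the series" means these few. Any claim that something is new, unique, unknown or untested is made for them only; others in the source may bear on it.

Three compounds were measured in a functional assay on A-375 cells (Homo sapiens) for cytotoxicity, read by MTT assay, with a stated time of 72 h; on this read-out higher numbers stand for weaker inhibition and lower numbers for stronger inhibition:

compound 1, `CC1(C)OCC(Cn2cc(Cn3c4c(c5ccccc53)C(=O)c3c[n+]([O-])c5ccccc5c3C4=O)nn2)O1`, gives 330 nM
compound 2, `O=C1c2c[n+]([O-])c3ccccc3c2C(=O)c2c1c1ccccc1n2CCCCN1CCNCC1`, gives 460 nM
compound 3, `O=C1c2c[n+]([O-])c3ccccc3c2C(=O)c2c1c1ccccc1n2Cc1cn([C@H]2C[C@H](O)[C@@H](CO)O2)nn1`, gives 390 nM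

Compound 1 has the lowest of the three numbers, but its gaps to compound 3 and to compound 2 both lie within the scatter, so no order can be read from them. Compound 4, `O=C1c2c[n+]([O-])c3ccccc3c2C(=O)c2c1c1ccccc1n2Cc1cn(C[C@@H](O)CO)nn1`, differs from compound 1 by 1,2-dihydroxyethyl in place of 2,2-dimethyl-1,3-dioxolan-4-yl on a saturated chain carbon bound to an aromatic nitrogen. Among the compounds with values here, the only measured step that touches the same place is a 1.2-fold higher number from compound 1 to compound 3 (0.07 log units; within the scatter), which swapped the same dioxolane-bearing group for a different hydroxylated group and stayed within the scatter. On that basis compound 4 is expected to show no step beyond the scatter, a 1.2-fold higher number from compound 1 to compound 4 (0.08 log units; within the scatter). Compound 4 is therefore estimated at 400 nM, with a range from 200 nM to 800 nM.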

Compound 4, half-maximal inhibitory concentration: 140 nM
Beside the measured number, compound 4's estimate is 2.9-fold (0.46 log units) above it, and the stated range ends above it.
By their numbers in this assay, from the lowest: compound 4; then compounds 1, 3 and 2 (each within the scatter of the next).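

In this assay, within the data shown here, the change from 2,2-dimethyl-1,3-dioxolan-4-yl to 1,2-dihydroxyethyl on a saturated chain carbon bound to an aromatic nitrogen gives the first step here beyond the scatter (a 2.4-fold lower number from compound 1 to compound 4 (0.37 log units; beyond the scatter)). The 2,3-dihydroxypropyl compound also separates from the other two (a 2.8-fold lower number from compound 3 to compound 4 (0.44 log units; beyond the scatter); a 3.3-fold lower number from compound 2 to compound 4 (0.52 log units; beyond the scatter)), so the group carried at this position does affect the read-out, if modestly. Nothing available explains this difference.

The compounds shown leave open whether both hydroxyl groups of 2,3-dihydroxypropyl are required, which a 2-hydroxyethyl group would test. On these data alone, whether an amine or a carboxylic acid could take their place also remains open.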